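Cytotoxicity notes: piperazine nitrogen substituents on a shared core

The source may hold more compounds than are shown below. What is called first, only, known or untested is meant among the compounds shown, and "the series" means these compounds.

Measured compounds:
compound 1, `O=[N+]([O-])c1ccc(C2=NOC(c3ccc(N4CCN(Cc5ccccn5)CC4)cc3)C2)o1`, in an ADME assay on WI-38 cells (Homo sapiens) for cytotoxicity, read by MTT assay, with a stated time of 96 h; a lower number here means a stronger inhibitor, a higher number a weaker inhibitor: > 50000 nM
compound 2, `CC(C)(C)OC(=O)N1CCN(c2ccc(C3CC(c4ccc([N+](=O)[O-])o4)=NO3)cc2)CC1`: > 50000 nM

Compound 1 gives only a limit of the assay in this assay, > 50000 nM. Compound 2 likewise gives only a limit, > 50000 nM. Both values sit at the limit of > 50000 nM in this assay, at which 2 of the 2 values shown sit, so the series has no number yet, only limits, and compound 2 stands at the limit like compound 1. Going by the values given here, the single step measured, a step that the two limits leave unreadable from compound 1 to compound 2, is therefore unreadable in size and direction.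

Compound 3, `O=[N+]([O-])c1ccc(C2=NOC(c3ccc(N4CCN(Cc5ccncc5)CC4)cc3)C2)o1`, is the next analogue, not yet measured. It differs from compound 2 by (pyridin-4-yl)methyl in place of tert-butoxycarbonyl on an amine nitrogen in a ring. The step from compound 1 to compound 2 bears on this change only as far as both of its ends are limits; it gives no size to carry over. No step beyond the scatter is therefore expected for a step that the limit leaves unreadable from compound 2 to compound 3, and a further limit is the most likely outcome. Compound 3 is expected to give 80000 nM, within a range from 30000 nM to 300000 nM.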

Compound 3, half-maximal inhibitory concentration: > 50000 nM
Compound 3 was reported as a limit; the forecaster's own chance of this, stated with the estimate: 85%; the middle value lies beyond the limit too.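

In this assay compound 3 gives > 50000 nM, which is a limit and not a number. The steps among compound 1, compound 2 and compound 3 cannot be read in size or direction: the limit of > 50000 nM in this assay, at which 3 of the 3 values shown sit.

The compounds shown leave open whether any group on the amine nitrogen in a ring gives a measurable value in this assay.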